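Methyl for Fluoro on the Aryl Piperazine Arm

The source may hold more compounds than are shown below. What is called first, only, known or untested is meant among the compounds shown, and "the series" means these compounds.

Three compounds share a core carrying a propyl group, a phenyl group, and an aryl piperazine reached through a linker amine. Compound 1 `CCCc1nc(-c2ccccc2)c(CNCCN2CCN(c3ccccc3F)CC2)o1` bears a fluoro substituent on the terminal aromatic ring; in an assay on HEK293 cells for inhibition of Voltage-dependent T-type calcium channel subunit alpha-1G (Homo sapiens), read by fluorescence, tested at 10 uM (a higher number here means more inhibition at the concentration tested (going by the name of the read-out), a lower number less inhibition), compound 1 gives 46.5%. Compound 2 `CCCc1nc(-c2ccccc2)c(CNCCN2CCN(c3ccccc3C)CC2)o1` replaces that fluoro with methyl, the change being (methyl in place of fluoro on an aromatic carbon), and in this assay compound 2 gives 51.3%. The step of a number 4.8 percentage points higher from compound 1 to compound 2 (within the scatter) is small. Compound 3 `CCCc1nc(-c2ccccc2)c(CNCCCN2CCN(c3ccccc3F)CC2)o1` keeps the fluoro but has a different core; the difference between the cores of compound 1 and compound 3 is not broken down here. In this assay compound 3 gives 54.4%, which lies within the scatter of both compound 1 and compound 2.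

Compound 4 `CCCc1nc(-c2ccccc2)c(CNCCCN2CCN(c3ccccc3C)CC2)o1` has not yet been measured. It differs from compound 3 by methyl in place of fluoro on an aromatic carbon, the same change seen between compound 1 and compound 2, at the same place. Because the step of a number 4.8 percentage points higher from compound 1 to compound 2 (within the scatter) was small, the step from compound 3 to compound 4 is expected to be of similar size, a number 3.6 percentage points higher from compound 3 to compound 4 (within the scatter). Compound 4 is therefore estimated to give 58% in this assay, with a range from 45% to 71% reflecting the usual scatter around a single-concentration reading.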

Compound 4, a percentage reported as inhibition, at one concentration (the size of the read-out at that concentration, not a potency): 54.5%
Compound 4: the middle estimate sits 3.5 percentage points above what was measured; the range from low to high includes it.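

On the core of compound 3, the change from 2-fluorophenyl to 2-methylphenyl gives, in this assay, a number 0.1 percentage points higher from compound 3 to compound 4 (within the scatter). Set beside the earlier step on the core of compound 1, the new step shows no difference that stands clear of the scatter: the same change on two cores in this assay, a number 4.8 percentage points higher (within the scatter) from compound 1 to compound 2 and a number 0.1 percentage points higher (within the scatter) from compound 3 to compound 4, 4.7 percentage points apart, within the scatter of two such steps. So, on these two cores, the swap of fluoro for methyl leaves the reading within the scatter both times, but this does not show that the change has a fixed size across the series, as two small steps at a single concentration cannot separate a shared small effect from no effect, say nothing about potency, and cover only two cores.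

The compounds shown leave open whether other groups at this place on the terminal ring, such as chloro, methoxy or an amine, would give a step beyond the scatter in this assay. They also leave open whether the swap of fluoro for methyl would stay this small on a core with a longer chain in the linker, or with something other than propyl on the core, such as a butyl chain.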